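Lengthening the alkyl carbamate chain in the diisopropylphenyl series

The source may report more compounds than this note shows. Statements on the series, on what has been measured and on what is new or still open speak of the compounds shown alone.

Compound 3 `CCCCCCCC(C)OC(=O)NC(=O)Oc1c(C(C)C)cccc1C(C)C` gives 97 nM in an assay on microsomes from intestine for inhibition of acyl-CoA:cholesterol acyltransferase (Oryctolagus cuniculus); on this read-out higher numbers stand for weaker inhibition and lower numbers for stronger inhibition. It stands second highest of the three numbers: compound 1 `CC(C)c1cccc(C(C)C)c1OC(=O)NC(=O)OCc1ccccc1` gives 77 nM, a gap within the scatter, a 1.3-fold higher number from compound 1 to compound 3 (0.10 log units; within the scatter), while compound 2 `CC(C)c1cccc(C(C)C)c1OC(=O)NC(=O)OCCCc1ccccc1` gives 660 nM, a 6.8-fold lower number from compound 2 to compound 3 (0.83 log units; beyond the scatter). Compound 4 `CCCCCCCCCCCCC(C)OC(=O)NC(=O)Oc1c(C(C)C)cccc1C(C)C` carries pentyl in place of hydrogen on a saturated chain carbon, eight bonds along the chain from an oxygen next to a carbonyl group. For the measured compounds named here, no measured step extends a saturated chain; the closest analogy is an 8.6-fold higher number from compound 1 to compound 2 (0.93 log units; beyond the scatter), where a longer link to the ring cost potency, whereas a 1.3-fold higher number from compound 1 to compound 3 (0.10 log units; within the scatter) shows an alkyl group matching a benzyl. The expected step is therefore small, a 1.6-fold higher number from compound 3 to compound 4 (0.22 log units; within the scatter), leaning weaker but uncertain. Compound 4 is estimated at 160 nM, with a range of 40 nM to 650 nM.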

Compound 4, half-maximal inhibitory concentration: 17 nM
Beside the measured number, compound 4's estimate is 9.4-fold (0.97 log units) above it, outside the stated range (below it).
By their numbers in this assay, from the lowest: compound 4; then compounds 1 and 3 (each within the scatter of the next); then compound 2.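

Pentyl in place of hydrogen on this saturated chain carbon gives a 5.7-fold lower number from compound 3 to compound 4 (0.76 log units; beyond the scatter) in this assay, so on this alkyl chain added length strengthens inhibition. The earlier loss on lengthening the link to the phenyl ring, an 8.6-fold higher number from compound 1 to compound 2 (0.93 log units; beyond the scatter), therefore does not carry over to this chain. Nothing measured here accounts for the gain.

From the compounds shown here alone, whether a longer chain keeps the gain, or a carboxylic acid at the chain end is tolerated, stays open. A single extension on the alkyl side places no best chain length.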